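This account rests on a few compounds, and the source may have more. Where it says the series, first, only, none or still open, it means among the compounds named here.

Compound 1 `CCCCCC(=O)NCC(=O)N(C)c1ccc(Cl)cc1C(=O)c1ccccc1Cl` gives 90 mg/kg in a functional assay on the whole organism with Mus musculus as the target, in the rotarod test; on this read-out higher numbers stand for an effect only at larger amounts of compound and lower numbers for an effect already at smaller amounts. Compound 2 `CN1CCN(CC(=O)NCC(=O)N(C)c2ccc(Cl)cc2C(=O)c2ccccc2Cl)CC1` reaches only a limit of the measurement, > 100 mg/kg, in this assay. Compound 3 `CN(C(=O)CNC(=O)CN)c1ccc(Cl)cc1C(=O)c1ccccc1Cl` gives 27.7 mg/kg in this assay.

Of the two real numbers shown, compound 3 has the lower one; its nearest neighbour is compound 1, and the step between them is a 3.2-fold lower number from compound 1 to compound 3 (0.51 log units; beyond the scatter). The third entry, that of compound 2, is a limit and not a number, and the step of an at least 3.6-fold lower number from compound 2 to compound 3 (0.55 log units; beyond the scatter) can therefore only be given as a floor.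

Compound 4 `CCCC(=O)NCC(=O)N(C)c1ccc(Cl)cc1C(=O)c1ccccc1Cl` is the next structure to be tested. It differs from compound 3 by ethyl in place of amino on a saturated chain carbon bound to a carbonyl carbon. The change concerns the same position as the two measured steps: putting amino in place of butyl gave a 3.2-fold lower number from compound 1 to compound 3 (0.51 log units; beyond the scatter), and putting amino in place of 4-methylpiperazin-1-yl gave an at least 3.6-fold lower number from compound 2 to compound 3 (0.55 log units; beyond the scatter). Here the amino group leaves and a short alkyl chain enters, which is the reverse sense of the first of those steps, though with ethyl rather than butyl. A modest rise in the number, in the direction of compound 1 but probably not as far, is therefore the expectation, that is a 2.2-fold higher number from compound 3 to compound 4 (0.34 log units; beyond the scatter). For compound 4 the expected value in this assay is 60 mg/kg, with a range from 25 mg/kg to 130 mg/kg.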

Compound 4, dose for half-maximal effect: 55.2 mg/kg
Compound 4: middle estimate off by 1.1-fold (0.04 log units), on the high side; low and high end bracket the measured number.
By their numbers in this assay, from the lowest: compounds 3, 4 and 1 (each within the scatter of the next, the first and the last beyond it). At a limit, above all of these: compound 2.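

In this assay, the step on exchanging the amino group for ethyl is a 2.0-fold higher number from compound 3 to compound 4 (0.30 log units; within the scatter), so at this place the two groups cannot be told apart, even though amino in place of butyl gave a step beyond the scatter, a 3.2-fold lower number from compound 1 to compound 3 (0.51 log units; beyond the scatter). The step from butyl to ethyl is a 1.6-fold lower number from compound 1 to compound 4 (0.21 log units; within the scatter), so the two alkyl chains cannot be told apart either, and the difference at this place only appears across the whole span from amino to butyl, with the ethyl compound falling within the scatter of both ends. One further step can be given only as a floor, an at least 1.8-fold lower number from compound 2 to compound 4 (0.25 log units; that floor lies within the scatter). Compound 2 gives only a limit and no number: the limit of > 100 mg/kg in this assay, at which 1 of the 4 values shown sits.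

The compounds shown leave open whether a chain longer than butyl, such as octyl, would continue the span seen from amino to butyl, or whether the ethyl compound's place within it would hold up on repeated measurement. As far as these compounds go, it also remains open where a carboxylic acid, a hydroxyl group or a small dimethylamino group would fall at this place, and whether the amino group itself matters or any short group would serve as well.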